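Isopropyl in place of isobutyl on the sulfur of compound 1

The source may report more compounds than this note shows. Statements on the series, on what has been measured and on what is new or still open speak of the compounds shown alone.

Working notes on the series. Compound 1 `CC(C)CSc1nc(N)nc2c1ncn2/C=C1/CC1(CO)CO` is the reference point in an ADME assay on Akata cells (Homo sapiens) for cytotoxicity, with a stated time of 7 days; on this read-out higher numbers stand for lower toxicity in this test and lower numbers for higher toxicity in this test. In this assay compound 1 gives > 20000 nM, which is a limit of the assay rather than a number. Compound 2 `CCCCNc1nc(N)nc2c1ncn2/C=C1/CC1(CO)CO` carries butylamino in place of isobutylsulfanyl on the aromatic carbon; in this assay compound 2 gives > 24000 nM, again a limit. Compound 3 `C=CCOc1nc(N)nc2c1ncn2/C=C1/CC1(CO)CO` carries allyloxy in place of isobutylsulfanyl on the aromatic carbon; in this assay compound 3 gives > 20000 nM, also a limit. Where compound 1 stands can be told no more closely than this: every value in the set is a limit, namely the limit of > 20000 nM in this assay, at which 2 of the 3 values shown sit, and (the limit of > 24000 nM in this assay, at which 1 of the 3 values shown sits). The steps a step that the two limits leave unreadable from compound 1 to compound 2, a step that the two limits leave unreadable from compound 1 to compound 3 and a step that the two limits leave unreadable from compound 2 to compound 3 accordingly have no readable size.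

Compound 4 `CC(C)Sc1nc(N)nc2c1ncn2/C=C1/CC1(CO)CO` differs from compound 1 by isopropyl in place of isobutyl on a sulfur. Within the data shown here, no measured step bears on this change with a readable size; the three measured compounds only show that three different groups on that aromatic carbon all leave the value at a limit of this assay. The step from compound 1 is therefore expected to be none beyond the scatter, a step that the limit leaves unreadable from compound 1 to compound 4. Compound 4 is expected to give about 25000 nM in this assay, within a range from 10000 nM to 60000 nM, and most probably to be reported only as a limit.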

Compound 4, half-maximal cytotoxic concentration: > 20000 nM
Compound 4: no number, only a limit; the forecaster's own chance of this, stated with the estimate: 80%; the middle value is on the limit's open side.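

Among these compounds, compound 4 gives only a limit of the assay, so no step to compound 4 from compound 1, compound 2 or compound 3 can be read: the limit of > 20000 nM in this assay, at which 3 of the 4 values shown sit. The compounds shown leave open where the actual value of any of these four compounds lies in this assay, and whether the different groups on the aromatic carbon differ at all there.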